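Naphthyl Replacement on the Ethoxycarbonyl-Bearing Urea Core

The compounds below may be only part of what the source reports. "The series", "measured", "known", "first", "only" and "open" are said of these compounds alone.

Compound 3 `CCOC(=O)c1cnn2c1N(C(=O)Nc1ccccc1F)C(c1ccccc1)C2` gives 116 nM in a functional assay on cells (Neutrophil, Homo sapiens) for inhibition, with a stated time of 10 min (a lower number here means a stronger inhibitor, a higher number a weaker inhibitor), the highest of the two numbers recorded there. Compound 1 `O=C(Nc1ccccc1F)N1c2ccnn2CC1c1ccccc1` gives 5.4 nM in this assay, so the step of a 21-fold higher number from compound 1 to compound 3 (1.33 log units; beyond the scatter) is large. Compound 2 `O=C(Nc1cccc2ccccc12)N1c2ccnn2CC1c1ccccc1` reaches only a limit in this assay, reported as > 1000 nM. Compound 4 `CCOC(=O)c1cnn2c1N(C(=O)Nc1cccc3ccccc13)C(c1ccccc1)C2` has not yet been measured; the change from compound 3 is naphthalen-1-yl in place of 2-fluorophenyl on an amide-type nitrogen. Among the compounds with values here, no single measured step covers this exchange directly, but compound 1 and compound 2 differ in the same way, and compound 2 gives only a limit of > 1000 nM in this assay, at which 1 of the 3 values shown sits, where compound 1 gives a number well inside the range. Starting from the already weaker compound 3, the step of a 170-fold higher number from compound 3 to compound 4 (2.24 log units; beyond the scatter) is expected to be large and upward. Compound 4 is therefore estimated at 20000 nM, within 2000 nM to 200000 nM.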

Compound 4, half-maximal inhibitory concentration: 13.8 nM
Beside the measured number, compound 4's estimate is 1400-fold (3.16 log units) above it; measured number below the stated range.
By their numbers in this assay, from the lowest: compound 1; then compound 4; then compound 3. At a limit, above all of these: compound 2.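

On the ethoxycarbonyl-bearing core, naphthalen-1-yl on the amide-type nitrogen gives a stronger inhibitor in this assay, with an 8.4-fold lower number from compound 3 to compound 4 (0.92 log units; beyond the scatter). Read against a limit, ethoxycarbonyl in place of hydrogen now also goes the opposite way, with an at least 72-fold lower number from compound 2 to compound 4 (1.86 log units; beyond the scatter). The two places therefore do not act independently in these compounds: the same change on two cores in this assay, a 21-fold higher number (1.33 log units; beyond the scatter) from compound 1 to compound 3 and an at least 72-fold lower number (1.86 log units; beyond the scatter) from compound 2 to compound 4, at least 1500-fold (3.19 log units) apart, beyond the scatter of two such steps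

As far as these compounds go, it remains open whether a carboxylic acid or a primary amide in place of ethoxycarbonyl would keep this reversal. From the compounds shown here alone, it is equally open whether the reversal extends to aryl groups on the urea other than 2-fluorophenyl and naphthalen-1-yl.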